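The source may hold more compounds than are shown below. What is called first, only, known or untested is meant among the compounds shown, and "the series" means these compounds.

Working notes on the series.

The set rests on a shared core carrying an acylated selenoimidate-type unit. Compound 1, `C[Se]/C(=N\C(=O)c1cc2ccccc2s1)NC(=O)c1cc2ccccc2s1`, in an ADME assay on MCF-10A cells (Homo sapiens) for cytotoxicity, read by MTT assay, with a stated time of 72 h (a lower number here means a stronger inhibitor of growth, a higher number a weaker inhibitor of growth), gives 34700 nM. Compound 2, `C[Se]/C(=N\C(=O)c1cccs1)NC(=O)c1cccs1`, gives 41100 nM in this assay. Compound 3, `O=C(/N=C(/NC(=O)c1cccs1)[Se]Cc1ccccc1)c1cccs1`, is known only as a limit of this assay, > 100000 nM, and so its place among the three can be told only in one direction. For the measured compounds named here, the single measured step, an at least 2.4-fold higher number from compound 2 to compound 3 (0.38 log units; beyond the scatter), is set by the limit of > 100000 nM in this assay, at which 1 of the 3 values shown sits; only a lower bound of that step is known.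

The next compound, compound 4, `CS/C(=N\C(=O)c1cccs1)NC(=O)c1cccs1`, differs from compound 3 by a group of 2 heavy atoms (1 carbon, 1 sulfur; no ring) in place of a group of 8 heavy atoms (7 carbon, 1 selenium; one six-membered aromatic ring of carbon only), on a carbon with a double bond to nitrogen. The change is not the exact reverse of the step from compound 2 to compound 3, since the selenium is exchanged as well, yet it leaves compound 4 as the closest structural neighbour of compound 2, whose value of 41100 nM is the anchor here. The measured step from compound 2 to compound 3 therefore suggests that removing the phenyl should bring the number back down from the limit. The expectation for compound 4 in this assay is 45000 nM, within 20000 nM to 100000 nM. This estimate corresponds to a step of an at least 2.2-fold lower number from compound 3 to compound 4 (0.34 log units; beyond the scatter), a drop, though whether the sulfur for selenium exchange adds anything is not known from the compounds measured.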

Compound 4, concentration for total growth inhibition: 55100 nM
Beside the measured number, compound 4's estimate is 1.2-fold (0.09 log units) below it, within the range that was stated.
By their numbers in this assay, from the lowest: compounds 1, 2 and 4 (each within the scatter of the next). At a limit, above all of these: compound 3.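

On the carbon with a double bond to nitrogen, the exchange of selenium for sulfur can now be read on its own: in this assay, methylsulfanyl in place of its selenium counterpart gives a 1.3-fold higher number from compound 2 to compound 4 (0.13 log units; within the scatter), so no separate effect of this exchange appears in these two compounds. Replacing the larger selenium group of compound 3 with methylsulfanyl gives an at least 1.8-fold lower number from compound 3 to compound 4 (0.25 log units; that floor lies within the scatter), and only this floor is known, as the step rests on a limit of the assay: the limit of > 100000 nM in this assay, at which 1 of the 4 values shown sits. Of the steps at this position, the phenyl step on the saturated chain carbon bound to selenium therefore remains the only one printed as beyond the scatter, while the sulfur for selenium exchange adds no step beyond it.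

The compounds shown leave open whether phenyl on a saturated chain carbon bound to sulfur would give a step like the one seen with selenium, since the phenyl step is known only on selenium. They also leave open how a longer chain such as propyl, or an amine, on this carbon would read in this assay.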